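From compound 3 to compound 4: one added methyl

This account rests on a few compounds, and the source may have more. Where it says the series, first, only, none or still open, it means among the compounds named here.

Compound 1 (`O=C1/C(=C/c2ccccc2)CCC/C1=C\c1ccccc1[N+](=O)[O-]`) gives 16000 nM
Compound 2 (`COc1cc(/C=C2\CCC/C(=C\c3ccccc3[N+](=O)[O-])C2=O)cc(OC)c1OC`) gives 35000 nM
Compound 3 (`O=C1/C(=C/c2ccccc2)CCC/C1=C\c1cccc([N+](=O)[O-])c1`) gives 14000 nM

All three numbers come from an ADME assay on HPC cells (Homo sapiens) for cytotoxicity, with a stated time of 24 h (on this read-out higher numbers stand for lower toxicity in this test and lower numbers for higher toxicity in this test), and no two of these compounds differ in one place only. Compound 3 stands at the low end of the three together with compound 1, the two lying within the scatter of each other. Compound 2 reads higher than compound 3, by a gap beyond the scatter.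

Compound 4 (`Cc1ccc(/C=C2\CCC/C(=C\c3cccc([N+](=O)[O-])c3)C2=O)cc1`) has not yet been measured. It departs from compound 3 by a single change. That change is methyl in place of hydrogen on an aromatic carbon and reads in words as methyl in place of hydrogen on an aromatic carbon, para to a large group, or phenyl to 4-methylphenyl.

No measured step among these compounds shows what such a change does, so the expectation rests on compound 3 at 14000 nM as the starting point. In this assay no shift beyond the scatter is expected, and the estimated move is a 1.1-fold higher number from compound 3 to compound 4 (0.03 log units; within the scatter) with no firm direction. For compound 4 the estimated value is 15000 nM with an expected range from 7000 nM to 32000 nM as the likely span.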

Compound 4, half-maximal cytotoxic concentration: 192000 nM
The estimate for compound 4 lay 13-fold (1.11 log units) below the measured number, and the stated range ends below it.
By their numbers in this assay, from the lowest: compounds 3 and 1 (each within the scatter of the next); then compound 2; then compound 4.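

In this assay, for the compounds shown here, the change from phenyl to 4-methylphenyl gives a 14-fold higher number from compound 3 to compound 4 (1.14 log units; beyond the scatter) and is the first step here between two compounds that differ in one place. Going by these compounds alone, it shows that one added methyl, on an aromatic carbon para to a large group, can by itself move this read-out by a large amount, towards lower toxicity in this test, which the earlier compounds could not show because no two of them stood a single change apart. Nothing at hand bears on what lies behind this step, so it stands as an observation about this one change.

The compounds shown leave open whether the step belongs to the methyl itself or would also appear with another group at the same place, such as an ethyl group, a fluorine atom or an amine. They also leave open whether the same added methyl would give a step of like size on compound 1 or compound 2, or whether it holds only with the ring substitution of compound 3.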